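Fluoro substitution on a phenylpiperazine series, tested in mice

This account rests on a few compounds, and the source may have more. Where it says the series, first, only, none or still open, it means among the compounds named here.

Compound 1 `FC(F)(F)c1cccc(N2CCN(CCCOc3ccc4c(c3)CCC4)CC2)c1` gives 73% in a functional assay on the whole organism for inhibition, with Mus musculus as the target, at a dose of 25 mg/kg by the oral route; a lower number here means less inhibition, a higher number more inhibition at the dose given (going by the name of the read-out). Compound 2 `Fc1cc2c(cc1OCCCN1CCN(c3cccc(C(F)(F)F)c3)CC1)CCC2` gives 20% in this assay, and the step of a number 53 percentage points lower from compound 1 to compound 2 (beyond the scatter) follows from the change (fluoro in place of hydrogen on an aromatic carbon). Compound 3 `Oc1cc2c(cc1OCCCN1CCN(c3ccccc3)CC1)CCC2` gives 0% in this assay; the difference between its core and the core of compound 1 is not broken down here. Compound 4 `Oc1cc2c(cc1OCCCN1CCN(c3ccc(F)cc3)CC1)CCC2` has not yet been measured in this assay. Within the data shown here, it differs from compound 3 by fluoro in place of hydrogen on an aromatic carbon, the same kind of change as the one from compound 1 to compound 2, but on a ring of carbon only that is not part of a fused system, para to a large group rather than ortho. Because compound 3 gives 0%, little room remains downward, so only a small step of a number 8 percentage points higher from compound 3 to compound 4 (within the scatter) is expected, giving an estimate for compound 4 of 8% in this assay, between 0% and 35%.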

Compound 4, a percentage reported as inhibition, in the whole organism at one dose (the size of the read-out at that dose, not a potency): 0%
The estimate for compound 4 lay 8 percentage points above the measured number; measured number inside the range.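

In this assay, fluoro in place of hydrogen on the phenyl ring gives no change at the digits printed from compound 3 to compound 4 (within the scatter). The same kind of change therefore does not carry over as a fixed step from one core to another in this series: the same change on two cores in this assay, a number 53 percentage points lower (beyond the scatter) from compound 1 to compound 2 and no change at the digits printed (within the scatter) from compound 3 to compound 4, 53 percentage points apart, beyond the scatter of two such steps

What this does not show is which difference between the two pairs sets the steps apart, and with compound 3 at 0%, a fall on this core could not be seen. The compounds shown leave open whether a different group in the same place, such as chloro or methoxy, would raise the number on this core. They also leave open whether a methoxy group in place of the hydroxyl would let a fluoro step appear.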